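Trifluoromethyl for Chloro on a Fatty Acid Receptor Agonist

The compounds below may be only part of what the source reports. "The series", "measured", "known", "first", "only" and "open" are said of these compounds alone.

Compound 1 `Cc1cccc(-c2nc(C)c(COc3ccc4c(c3)OCC4CC(=O)O)s2)c1` is measured in a functional assay on CHO cells for agonist activity at Free fatty acid receptor 1 (Homo sapiens), read by FLIPR and calcium flux, tested at 100 nM (a lower number here means a weaker effect, a higher number a stronger effect of the compound at the concentration tested), where compound 1 gives 47.2%. Compound 2 `Cc1nc(-c2ccc(Cl)cc2)sc1COc1ccc2c(c1)OCC2CC(=O)O` carries 4-chlorophenyl in place of 3-methylphenyl on an aromatic carbon, and in this assay compound 2 gives 53.4%. The step of a number 6.2 percentage points higher from compound 1 to compound 2 (within the scatter) lies within the scatter, so compound 2 stands as the higher of the two numbers only in name, with compound 1 sitting within the usual spread of it.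

Compound 3 `Cc1nc(-c2ccc(C(F)(F)F)cc2)sc1COc1ccc2c(c1)OCC2CC(=O)O` differs from compound 2 by trifluoromethyl in place of chloro on an aromatic carbon. Among the compounds with values here, no measured step changes this same position, and the only step seen, a number 6.2 percentage points higher from compound 1 to compound 2 (within the scatter), was within the scatter. The step of a number 1.6 percentage points higher from compound 2 to compound 3 (within the scatter) is therefore expected to stay small, without a clear direction beyond the scatter. In this assay compound 3 is estimated at 55%, with a range from 35% to 75%.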

Compound 3, a percentage reported as activity, at one concentration (the size of the read-out at that concentration, not a potency): 50.4%
The estimate for compound 3 lay 4.6 percentage points above the measured number; the range from low to high includes it.
By their numbers in this assay, from the lowest: compounds 1, 3 and 2 (each within the scatter of the next).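

In this assay, within the data shown here, the first change at this position, from chloro to trifluoromethyl (1 heavy atom leaving, 4 entering), gives a number 3 percentage points lower from compound 2 to compound 3 (within the scatter), so the larger group leaves the read-out indistinguishable from that of chloro. The comparison with the 3-methylphenyl compound gives a number 3.2 percentage points higher from compound 1 to compound 3 (within the scatter), so 4-(trifluoromethyl)phenyl, like 4-chlorophenyl, cannot be separated from 3-methylphenyl in this assay. No measurement here bears on why these groups read alike.

An amine, a carboxylic acid or a longer carbon chain at this position could show whether the read-out can move beyond the scatter here at all. The read-out also comes from a single concentration, so it leaves open whether compound 2 and compound 3 would also match in potency.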